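A few compounds are considered here, and "the series" means these few. Any claim that something is new, unique, unknown or untested is made for them only; others in the source may bear on it.

In a functional assay on HeLa cells (Homo sapiens) for cytotoxicity, read by MTT assay (a lower number here means a stronger inhibitor, a higher number a weaker inhibitor), compound 2 `CC(=O)c1ccc2c(c1O)[C@@H]1c3c(ccc4c(=O)c(C)c(C)oc34)OC[C@@H]1C(C)(C)O2` reaches only the limit > 100000 nM. Compound 1 `CCC(=O)c1ccc2c(c1O)[C@@H]1c3c(ccc4c(=O)c(C)c(C)oc34)OC[C@@H]1C(C)(C)O2` likewise gives only the limit > 100000 nM. Compound 3 `Cc1oc2c3c(ccc2c(=O)c1C)OC[C@H]1[C@@H]3c2c(ccc(C(=O)c3ccccc3)c2O)OC1(C)C` also stops at the limit > 100000 nM. All three sit at the limit of > 100000 nM in this assay, at which 3 of the 3 values shown sit, so the steps a step that the two limits leave unreadable from compound 1 to compound 2, a step that the two limits leave unreadable from compound 1 to compound 3 and a step that the two limits leave unreadable from compound 2 to compound 3 cannot be sized. Compound 4 `CC(=O)c1ccc2c(c1O)[C@@H]1c3c(ccc4c(=O)c(-c5ccccc5)c(C)oc34)OC[C@@H]1C(C)(C)O2` differs from compound 2 by phenyl in place of methyl on an aromatic carbon. Among the compounds with values here, no measured step bears readably on a phenyl at this place on the shared core; the nearest, a step that the two limits leave unreadable from compound 2 to compound 3, puts a phenyl on a carbonyl carbon and stays unreadable. With every value shown at the limit, compound 4 is expected to remain near it, a step that the limit leaves unreadable from compound 2 to compound 4 in this assay. The estimate for compound 4 is 150000 nM, between 30000 nM and 1000000 nM.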

Compound 4, half-maximal inhibitory concentration: 4810 nM
Beside the measured number, compound 4's estimate is 31-fold (1.49 log units) above it; the whole stated range lies above it.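

In this assay, within the data shown here, phenyl in place of methyl on this aromatic carbon gives an at least 20-fold lower number from compound 2 to compound 4 (1.31 log units; beyond the scatter), the first readable step; the steps among compound 1, compound 2 and compound 3 cannot be read. This position therefore responds to a change in a way that the changes on the carbonyl carbon never showed. Compound 4 is the only compound shown that comes off the limit: the limit of > 100000 nM in this assay, at which 3 of the 4 values shown sit.

The compounds shown leave open whether an ethyl, a longer chain or an amine at this position would also give a readable value. Also open, going by these compounds, is whether phenyl here gives a similar step with ethyl or phenyl on the carbonyl carbon.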